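Chlorine on the benzyl ring: cytotoxicity in keratinocytes

The source may report more compounds than this note shows. Statements on the series, on what has been measured and on what is new or still open speak of the compounds shown alone.

Measured compounds:
compound 1, `Cc1cc(S(=O)(=O)/N=C(\N)n2nccc2-c2ccccc2)c(SCc2ccccc2)cc1Cl`, 18000 nM;
compound 2, `Cc1cc(-c2ccccc2)n(/C(N)=N/S(=O)(=O)c2cc(C)c(Cl)cc2SCc2ccccc2)n1`, 10000 nM;
compound 3, `Cc1cc(-c2ccccc2)n(/C(N)=N/S(=O)(=O)c2cc(C)c(Cl)cc2SCc2ccc(Cl)cc2)n1`, 11000 nM.

The three compounds share one core and were tested in an ADME assay on HaCaT cells (Homo sapiens) for cytotoxicity, read by MTT assay, with a stated time of 72 h; on this read-out higher numbers stand for weaker inhibition and lower numbers for stronger inhibition. Compound 1 sits at the upper end of the three numbers, but its gaps to compound 2 and to compound 3 are both within the scatter, so no ordering among them can be read from these values. The step of a 1.8-fold lower number from compound 1 to compound 2 (0.26 log units; within the scatter) adds a methyl group; the step of a 1.1-fold higher number from compound 2 to compound 3 (0.04 log units; within the scatter) is a chloro in place of hydrogen on an aromatic carbon, and it left the number essentially where it was.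

Compound 4, `Cc1cc(S(=O)(=O)/N=C(\N)n2nccc2-c2ccccc2)c(SCc2ccccc2Cl)cc1Cl`, differs from compound 1 by chloro in place of hydrogen on an aromatic carbon. Going by the values given here, the step from compound 2 to compound 3 is the only measured step of the same kind, and it stayed within the scatter. Compound 4 is therefore expected to show no change at the digits printed from compound 1 to compound 4 (within the scatter), a step of no consequence beyond the scatter. The estimate for compound 4 in this assay is 18000 nM, with a range from 9000 nM to 36000 nM.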

Compound 4, half-maximal inhibitory concentration: 20000 nM
Compound 4: middle estimate off by 1.1-fold (0.05 log units), on the low side; measured number inside the range.
By their numbers in this assay, from the lowest: compounds 2, 3, 1 and 4 (each within the scatter of the next).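

In this assay, going from benzylsulfanyl to (2-chlorobenzyl)sulfanyl gives a 1.1-fold higher number from compound 1 to compound 4 (0.05 log units; within the scatter), so a chloro on this aromatic carbon, ortho to a large group, leaves the number within the scatter. Before this result, the change had been seen on only one core, the methyl-bearing core of compound 2, and it has now been seen on a second core that lacks that methyl, with the two steps in close agreement: the same change on two cores in this assay, a 1.1-fold higher number (0.04 log units; within the scatter) from compound 2 to compound 3 and a 1.1-fold higher number (0.05 log units; within the scatter) from compound 1 to compound 4, 1.0-fold (0.00 log units) apart, within the scatter of two such steps. Across these two pairs, adding a chloro to the benzyl ring has not moved the cytotoxicity number beyond the scatter, and neither pair goes against this, though two pairs are a narrow base.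

The compounds shown leave open whether a different group on this same carbon, such as an amine, a carboxylic acid or a longer chain in place of the chloro, would move the number beyond the scatter. They also leave open how a 2-chlorobenzyl group would read on the core of compound 2, and what in these structures, if anything, governs the number in this cell line.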